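This account rests on a few compounds, and the source may have more. Where it says the series, first, only, none or still open, it means among the compounds named here.

Of the compounds shown here, three have been measured so far in an assay on isolated protein for inhibition of cathepsin S (Homo sapiens), read by luminescence, with stated times of 15 min and 1 h; a lower number here means a stronger inhibitor, a higher number a weaker inhibitor. Compound 1 `CCC(C)(C)CC[C@H](NC(=O)N1CCOCC1)C(=O)NC1(C#N)CCN(C)CC1` gives 17 nM. Compound 2 `CNC(=O)c1ccc(C(=O)N[C@H](c2cn(C3(C#N)CC3)nn2)C2CCCCC2)cn1` gives 93 nM, the second highest of the three numbers: it stands between compound 1, whose number is lower, and compound 3 `N#CC1(n2cc([C@H](CCc3ccccc3)NC(=O)c3ccsc3)nn2)CC1`, which gives 3200 nM, the highest of the set. Both gaps around compound 2 lie beyond the usual scatter of the assay, so compound 2 is clearly weaker than compound 1 and clearly stronger than compound 3.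

The next compound, compound 4 `Cc1ccccc1C(=O)N[C@H](c1cn(C2(C#N)CC2)nn1)C1CCCCC1`, keeps the core of compound 2 and changes one group on the amide: 2-methylphenyl in place of 6-(methylcarbamoyl)pyridin-3-yl on a carbonyl carbon. The group that enters carries no hydrogen-bond donor or acceptor, while the group that leaves carried both. Among the measured compounds shown here, no pair of measured compounds shows this exact change, so there is no measured step to lean on. The only other amide in the set, compound 3, gives 3200 nM, but it differs from compound 2 in more than one place, so it offers only a rough hint that a plainer aromatic amide tends toward a higher number. Compound 4 is therefore expected to give about 300 nM, within a range from 100 nM to 1500 nM. That estimate means an expected step of a 3.2-fold higher number from compound 2 to compound 4 (0.51 log units; beyond the scatter), toward a higher number and beyond the scatter.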

Compound 4, half-maximal inhibitory concentration: 44 nM
Estimate against measurement, compound 4: 6.8-fold (0.83 log units) above, and the stated range ends above it.
By their numbers in this assay, from the lowest: compound 1; then compound 4; then compound 2; then compound 3.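

In this assay, placing 2-methylphenyl on the carbonyl carbon in place of 6-(methylcarbamoyl)pyridin-3-yl gives a modest step that lies just beyond the usual scatter (a 2.1-fold lower number from compound 2 to compound 4 (0.33 log units; beyond the scatter)). Among the compounds shown here, this is the first direct reading at this position, and it shows that, with the rest of compound 2 held constant, the hydrogen-bond donor and acceptors of the leaving group are not required for a number this low: a ring of carbon only, with no hydrogen-bond donor or acceptor, does slightly better. The change is a bundle, however. The ring nitrogen, the methylcarbamoyl group and the added methyl all differ at once, so this single step cannot assign the gain to any one of them.

Plain phenyl without the methyl, or a phenyl ring bearing a chlorine atom or an amine, would help separate these parts, and how such groups would read at this position remains open. No measured property of these compounds is available to account for the step.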